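Sulfonyl substituent change in the macrocyclic series: cytotoxicity outlook

The source may report more compounds than this note shows. Statements on the series, on what has been measured and on what is new or still open speak of the compounds shown alone.

Compound 3 `C#C[C@@H]1CCCN1S(=O)(=O)NC(=O)[C@@]12C[C@H]1/C=C\CCCCN(C)C(=O)N[C@@H](CCOc1cc(-c3nc(C(C)C)cs3)nc3c(Cl)c(OC)ccc13)C(=O)N2` carries a 2-ethynylpyrrolidin-1-yl group on the sulfonyl sulfur. In an ADME assay on cells (Homo sapiens) for activation (on this read-out higher numbers stand for lower toxicity in this test and lower numbers for higher toxicity in this test), compound 3 gives 21200 nM, the lowest of the three numbers measured in this set. Compound 1 `COc1ccc2c(OCC[C@@H]3NC(=O)N(C)CCCC/C=C\[C@@H]4C[C@@]4(C(=O)NS(=O)(=O)C4(F)CC4)NC3=O)cc(-c3nc(C(C)C)cs3)nc2c1Cl` gives 51400 nM and compound 2 `CCC1(S(=O)(=O)NC(=O)[C@@]23C[C@H]2/C=C\CCCCN(C)C(=O)N[C@@H](CCOc2cc(-c4nc(C(C)C)cs4)nc4c(Cl)c(OC)ccc24)C(=O)N3)CC1` gives 49300 nM; the two differ only by ethyl in place of fluoro on a saturated ring carbon, and the step of a 1.0-fold lower number from compound 1 to compound 2 (0.02 log units; within the scatter) falls within the scatter. Both cyclopropyl-bearing compounds sit above compound 3: the step of a 2.4-fold lower number from compound 1 to compound 3 (0.38 log units; beyond the scatter) and the step of a 2.3-fold lower number from compound 2 to compound 3 (0.37 log units; beyond the scatter) are modest but beyond the scatter.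

Compound 4 `COc1ccc2c(OCC[C@@H]3NC(=O)N(C)CCCC/C=C\[C@@H]4C[C@@]4(C(=O)NS(=O)(=O)C4(C#N)CC4)NC3=O)cc(-c3nc(C(C)C)cs3)nc2c1Cl` differs from compound 3 by 1-cyanocyclopropyl in place of 2-ethynylpyrrolidin-1-yl on a sulfonyl sulfur. This change goes in the opposite direction to the two measured steps toward compound 3, returning a three-membered carbon ring to the sulfonyl sulfur, now bearing a nitrile. Since compound 1 with 51400 nM and compound 2 with 49300 nM lie close together whatever the cyclopropyl substituent, the expected step of a 2.1-fold higher number from compound 3 to compound 4 (0.33 log units; beyond the scatter) is a modest rise in this assay back toward their level. For compound 4 the estimate in this assay is 45000 nM, with a range from 20000 nM to 90000 nM.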

Compound 4, half-maximal cytotoxic concentration: > 75000 nM
Compound 4 was reported as a limit; the forecaster's own chance of this, stated with the estimate: 10%; middle value at least 1.6-fold (0.22 log units) away from the limit.
By their numbers in this assay, from the lowest: compound 3; then compounds 2 and 1 (each within the scatter of the next). At a limit, above all of these: compound 4.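

In this assay compound 4 is reported as a limit and not as a number: the limit of > 75000 nM in this assay, at which 1 of the 4 values shown sits. On the sulfonyl sulfur, replacing 2-ethynylpyrrolidin-1-yl with 1-cyanocyclopropyl gives an at least 3.5-fold higher number from compound 3 to compound 4 (0.54 log units; beyond the scatter) and is beyond the scatter, so the lower number of compound 3 now stands against three cyclopropyl-bearing compounds and not only two, and a nitrile on that ring carbon brings no return toward lower numbers. Among the cyclopropyl-bearing compounds, the steps of an at least 1.5-fold higher number from compound 2 to compound 4 (0.18 log units; that floor lies within the scatter) and an at least 1.4-fold higher number from compound 1 to compound 4 (0.16 log units; that floor lies within the scatter) have floors within the scatter, so cyano on the saturated ring carbon may stand higher than ethyl or fluoro, but this is not established.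

The compounds shown leave open how far the reading of compound 4 extends past its limit, and whether the difference from compound 3 follows the three-membered carbon ring itself or the 2-ethynyl group on the pyrrolidine. An unsubstituted cyclopropyl, a plain pyrrolidin-1-yl or a dimethylamino group on the sulfonyl sulfur would help separate these two readings.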